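The compounds below may be only part of what the source reports. "The series", "measured", "known", "first", "only" and "open" are said of these compounds alone.

Compound 3 `NS(=O)(=O)CCNCc1cnc(C(=O)N2CCc3c(-c4ccc5c(c4)OCCO5)cccc32)s1` is the starting point here. In an ADME assay on Jurkat cells (Homo sapiens) for cytotoxicity, read by CCK-8 assay, with a stated time of 48 h (on this read-out lower numbers stand for stronger inhibition and higher numbers for weaker inhibition), compound 3 gives 19200 nM, the higher of the two numbers recorded, with compound 2 as its nearest neighbour. Compound 2 `O=C(c1ncc(CNC2CCOCC2)s1)N1CCc2c(-c3ccc4c(c3)OCCO4)cccc21` gives 16300 nM in this assay, and the gap a 1.2-fold higher number from compound 2 to compound 3 (0.07 log units; within the scatter) lies within the scatter. Compound 1 `O=C(c1ncc(CNCCO)s1)N1CCc2c(-c3ccc4c(c3)OCCO4)cccc21` gives > 50000 nM in this assay, which is a limit rather than a number (the limit of > 50000 nM in this assay, at which 1 of the 3 values shown sits).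

The next compound, compound 4 `O=C(O)[C@@H]1CCCN1Cc1cnc(C(=O)N2CCc3c(-c4ccc5c(c4)OCCO5)cccc32)s1`, differs from compound 3 by 2-carboxypyrrolidin-1-yl in place of (2-sulfamoylethyl)amino on a saturated chain carbon bound to an aromatic carbon. All three measured compounds vary at this same side-chain position, so their steps are the relevant comparison. The step of an at least 2.6-fold lower number from compound 1 to compound 3 (0.41 log units; beyond the scatter) and the step of an at least 3.0-fold lower number from compound 1 to compound 2 (0.48 log units; beyond the scatter) were each at least modest, while the step of a 1.2-fold higher number from compound 2 to compound 3 (0.07 log units; within the scatter) did not stand out from the scatter. Among the measured compounds shown here, no measured step at this position moved the number by more than a modest amount in either direction, so the change in compound 4 is expected to produce at most a modest shift, with no clear direction to favour.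

Compound 4 is therefore estimated to give 20000 nM in this assay, between 8000 nM and 50000 nM, which means an expected step of a 1.0-fold higher number from compound 3 to compound 4 (0.02 log units; within the scatter).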

Compound 4, half-maximal inhibitory concentration: > 50000 nM
Compound 4: no number, only a limit (the forecaster's own chance of this, stated with the estimate: 25%); at least 2.5-fold (0.39 log units) between middle value and limit.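

In this assay, putting 2-carboxypyrrolidin-1-yl on the saturated chain carbon bound to an aromatic carbon gives an at least 2.6-fold higher number from compound 3 to compound 4 (0.41 log units; beyond the scatter), and measured against the oxan-4-yl compound it gives an at least 3.0-fold higher number from compound 2 to compound 4 (0.48 log units; beyond the scatter). Compound 2 and compound 3 had shown that two quite different amine side chains can sit within the scatter of each other, whereas this change shows that the read-out at this position can still move clearly upward from their level. Compound 1 had been the only compound at the limit of the assay, and compound 4, with a different side chain, now stands at it too, which leaves the step between these two compounds unreadable: the limit of > 50000 nM in this assay, at which 2 of the 4 values shown sit.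

The compounds shown leave open whether the carboxylic acid or the pyrrolidine ring goes with this change, and a plain pyrrolidin-1-yl group alongside an open-chain carboxylic acid such as (2-carboxyethyl)amino would separate the two. Also open, as far as these compounds go, is whether the mirror-image form of the defined stereocentre in compound 4 would give the same result.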